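Trading the Acid-Bearing Tail for a Methoxyphenyl

The compounds below may be only part of what the source reports. "The series", "measured", "known", "first", "only" and "open" are said of these compounds alone.

Three compounds here were tested in an assay for positive allosteric modulation of metabotropic glutamate receptor 3 (Rattus norvegicus); a lower number here means that less compound is needed, a higher number that more compound is needed for the effect. Compound 1 `Cc1ncc(OCCCCOc2ccc(C(=O)CC(C)(C)C)c(O)c2C)cc1C(=O)O` gives 79 nM in this assay. Compound 2 `Cc1c(OC[C@@H](C)COc2cc(C(=O)O)ccc2F)ccc(C(=O)CC(C)(C)C)c1O` gives 3950 nM, the higher of the two numbers; the gap to compound 1 lies beyond the usual scatter. Compound 3 `COc1ccc(C(=O)N(C)C)cc1OC[C@H](C)COc1ccc(C(=O)CC(C)(C)C)c(O)c1C` is reported in this assay as "not active" (no number reported), with no number attached. Compound 4 `COc1cccc(OC[C@H](C)COc2ccc(C(=O)CC(C)(C)C)c(O)c2C)c1` has not yet been measured. It differs from compound 2 in one place: 3-methoxyphenyl in place of 5-carboxy-2-fluorophenyl on an oxygen on a saturated carbon. Among the compounds with values here, no measured pair shows this exact change, so the expectation rests on what is known. Within the data shown here, both numbered compounds carry a carboxy group, and the one compound without it, compound 3, stands at "not active" (no number reported). Compound 4 also lacks the carboxy group, so a step toward a higher number, beyond the scatter, is expected, with a real chance that no number is obtained at all. The expected step in this assay is a 7.6-fold higher number from compound 2 to compound 4 (0.88 log units; beyond the scatter). For compound 4 the estimate is 30000 nM in this assay, within a range of 8000 nM to 150000 nM.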

Compound 4, half-maximal effective concentration: "not active" (no number reported)
No number was reported for compound 4, and the estimate cannot be compared.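

Within the data shown here, compound 4 comes out in this assay as "not active" (no number reported) and so no step from compound 2 to compound 4 can be read. Still open, going by these compounds, is how large the change from 5-carboxy-2-fluorophenyl to 3-methoxyphenyl really is. Nothing measured here explains the result.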